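This account rests on a few compounds, and the source may have more. Where it says the series, first, only, none or still open, it means among the compounds named here.

In a physicochemical assay for acid dissociation, read by capillary electrophoresis, compound 2 `C[C@@]1(c2cc(NC(=O)c3ccc(C#N)cn3)ccc2F)C=COC(N)=N1` gives 7.7 and compound 1 `COCC1=C[C@@](C)(c2cc(NC(=O)c3ccc(C#N)cn3)ccc2F)N=C(N)O1` gives 7.4, two values within the usual scatter of each other. Compound 3 `C[C@@]1(c2cc(NC(=O)c3ccc(C#N)cn3)ccc2F)C=C(CF)OC(N)=N1` differs from compound 2 by fluoromethyl in place of hydrogen on a double-bonded ring carbon, with fluoromethyl in place of hydrogen on a double-bonded ring carbon. For the measured compounds named here, one measured step bears on this change: a number 0.30 log units higher from compound 1 to compound 2 (within the scatter), which swaps methoxymethyl for hydrogen on that kind of carbon. Read in reverse, it hints weakly that a group there goes with a lower number. The expected shift is small and downward, a number 0.40 log units lower from compound 2 to compound 3 (beyond the scatter). For compound 3 the estimated value is 7.3, within an expected range of 7 to 7.6.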

Compound 3, acid dissociation constant: 6.9
For compound 3 the middle estimate is 0.40 log units above the measured one; measured number below the stated range.
By their numbers in this assay, from the lowest: compound 3; then compounds 1 and 2 (each within the scatter of the next).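

In this assay, placing a group on this double-bonded ring carbon now gives a step beyond the scatter (a number 0.80 log units lower from compound 2 to compound 3 (beyond the scatter)), which the methoxymethyl and hydrogen pair did not show. The identity of the group also matters, as fluoro in place of methoxy on the chain carbon gives a clear step too (a number 0.50 log units lower from compound 1 to compound 3 (beyond the scatter)). Nothing shown here explains these shifts. The compounds shown leave open how difluoromethyl or trifluoromethyl on this carbon would compare with fluoromethyl. They also leave open where a simple methyl, an amine or a carboxylic acid there would fall.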